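The source may hold more compounds than are shown below. What is called first, only, known or untested is meant among the compounds shown, and "the series" means these compounds.

Measured compounds in an ADME assay on a cell-free system (plasma, Rattus norvegicus), with a stated time of 60 min; a lower number here means that less of the compound is left, a higher number that more of the compound is left:

compound 1 `O=C(O)c1cc(-c2cccc(COc3ccc4c(=O)n(C5CCCC5)oc4c3)c2)ccc1Cl`, 100%
compound 2 `O=C(O)c1cc(-c2cccc(COc3ccc4c(c3)CN(CC3CC3)C4=O)c2)ccc1Cl`, 100%
compound 3 `O=C(O)c1cc(-c2cccc(COc3ccc4c(c3)CN(c3ccccc3)C4=O)c2)ccc1Cl`, 100%

All three measured compounds sit at the same level in this assay; the values of compound 1, compound 2 and compound 3 lie within the scatter of one another, so no order among them can be read. Among the compounds with values here, the only step between compounds differing in one place is no change at the digits printed from compound 2 to compound 3 (within the scatter), which concerns the same amide-type nitrogen that is varied in the next compound.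

Compound 4 `O=C(O)c1cc(-c2cccc(COc3ccc4c(c3)CN(Cc3ccc(C(F)(F)F)cc3)C4=O)c2)ccc1Cl` is not yet measured. It differs from compound 3 by 4-(trifluoromethyl)benzyl in place of phenyl on an amide-type nitrogen in a ring. Within the data shown here, the one step that bears on this change, the swap of cyclopropylmethyl for phenyl at the same nitrogen, stayed within the scatter, and the substituents on that nitrogen span a cyclopropylmethyl, a phenyl and the cyclopentyl-bearing isomeric core of compound 1 without any movement in the read-out. On these numbers no step beyond the scatter is expected for the benzyl variant either; the expected step of a number 2 percentage points lower from compound 3 to compound 4 (within the scatter) is flat.

For compound 4 the estimate in this assay is 98%, with a range from 85% to 100%.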

Compound 4, percent of the compound remaining: 100%
Compound 4: middle estimate off by 2 percentage points, on the low side, and the stated range covers the measured number.
By their numbers in this assay, from the lowest: compounds 1, 2, 3 and 4 (each within the scatter of the next).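

In this assay, 4-(trifluoromethyl)benzyl on the amide-type nitrogen in a ring, with 11 heavy atoms including 3 fluorine against 6 carbon atoms for phenyl, gives no change at the digits printed from compound 3 to compound 4 (within the scatter), so this position now carries a substantially larger substituent with no separation in the read-out. The comparison on the saturated chain carbon bound to that nitrogen, 4-(trifluoromethyl)phenyl in place of cyclopropyl, gives no change at the digits printed from compound 2 to compound 4 (within the scatter), which extends the flat picture in this assay from a directly attached phenyl to an aromatic ring held on that chain carbon. No measured information is available to explain this flat result.

Whether an amine or a longer chain on the same nitrogen would separate from these compounds in this assay remains open, as does the effect of an ester in place of the carboxylic acid that all the compounds shown carry. With all four compounds reading alike, the series gives no order among its substituents and does not show which structural feature, if any, governs the read-out.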